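A few compounds are considered here, and "the series" means these few. Any claim that something is new, unique, unknown or untested is made for them only; others in the source may bear on it.

Of the compounds shown here, three built on one shared core have been measured in a physicochemical assay for solubility; a higher number here means a more soluble compound, a lower number a less soluble compound. Compound 1, `O=C(O)c1ccc(C(=O)/C(=C\c2ccc(F)c([N+](=O)[O-])c2)S(=O)(=O)Cc2ccc(Br)cc2)cc1`, reaches only a limit of the assay: in this assay compound 1 gives < 1000 ug/mL. Compound 2, `O=C(O)c1ccc(C(=O)/C(=C\c2ccc(Cl)c([N+](=O)[O-])c2)SCc2ccc(Cl)cc2)cc1`, likewise stands at a limit, and in this assay compound 2 gives < 1000 ug/mL. Compound 3, `O=C(O)c1ccc(C(=O)/C(=C\c2ccc(Br)c([N+](=O)[O-])c2)SCc2ccc(Br)cc2)cc1`, is the starting point of the step followed here, and it too stands at a limit; in this assay compound 3 gives < 1000 ug/mL. For the measured compounds named here, no two of the measured compounds differ from each other in a single place, and no step between measured compounds can be read from them. What the three readings have in common is the limit of < 1000 ug/mL in this assay, at which 3 of the 3 values shown sit, and nothing among them separates compound 3 from the other two.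

The unmeasured compound 4 is `O=C(O)c1ccc(C(=O)/C(=C\c2ccc([N+](=O)[O-])cc2F)SCc2ccc(Br)cc2)cc1`. It differs from compound 3 in one place: 2-fluoro-4-nitrophenyl in place of 4-bromo-3-nitrophenyl on a double-bonded chain carbon bound to a double-bonded chain carbon. Going by the values given here, with no measured step to rest on, the change is expected to move the reading by little, none beyond the usual scatter, and the step is estimated as a step that the limit leaves unreadable from compound 3 to compound 4. For compound 4 the expected value in this assay is 300 ug/mL, with a range from 50 ug/mL to 1000 ug/mL, and it is expected that the assay may again report only a limit.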

Compound 4, solubility: < 1000 ug/mL
Compound 4: no number, only a limit (the forecaster's own chance of this, stated with the estimate: 75%); the middle value lies beyond the limit too.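

Compound 3 and compound 4 both stand at a limit in this assay, so no step can be read between them: the limit of < 1000 ug/mL in this assay, at which 4 of the 4 values shown sit.

The compounds shown leave open how soluble any of them actually is, and whether 2-fluoro-4-nitrophenyl in place of 4-bromo-3-nitrophenyl shifts the reading at all.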